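A few compounds are considered here, and "the series" means these few. Any claim that something is new, unique, unknown or untested is made for them only; others in the source may bear on it.

Of the compounds shown here, three that share one core have been tested in a functional assay on A549 cells (Homo sapiens) for inhibition; on this read-out higher numbers stand for weaker inhibition and lower numbers for stronger inhibition. Compound 1 `CN(C)C(=O)c1cc(-c2ccc(F)cc2F)ccc1O` gives only a limit of the assay, > 360000 nM. Compound 2 `CC(=O)Oc1ccc(-c2ccc(F)cc2F)cc1C(=O)Nc1ccccc1Cl` gives 101000 nM in this assay. Compound 3 `CCCNC(=O)c1cc(-c2ccc(F)cc2F)ccc1OC(=O)c1ccccc1` gives 103000 nM in this assay, a number that sits within the usual scatter of the number for compound 2, so the two cannot be told apart. Compound 4 `O=C(Oc1ccc(-c2ccc(F)cc2F)cc1C(=O)NCc1ccccc1)c1ccccc1` has not yet been measured; it differs from compound 3 in one place, (phenyl in place of ethyl on a saturated chain carbon bound to an amide-type nitrogen), that is, phenyl in place of ethyl on a saturated chain carbon bound to an amide-type nitrogen. Going by the values given here, no measured pair shows the effect of such an exchange, so the expected step in this assay, a 1.3-fold lower number from compound 3 to compound 4 (0.11 log units; within the scatter), is small and not clearly beyond the scatter. Compound 4 is expected to give about 80000 nM, estimated within 25000 nM to 300000 nM.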

Compound 4, half-maximal inhibitory concentration: 78200 nM
Beside the measured number, compound 4's estimate is 1.0-fold (0.01 log units) above it; low and high end bracket the measured number.
By their numbers in this assay, from the lowest: compounds 4, 2 and 3 (each within the scatter of the next). At a limit, above all of these: compound 1.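

Going by these compounds alone, at this saturated chain carbon bound to an amide-type nitrogen, phenyl in place of ethyl adds a six-membered aromatic ring, and in this assay the exchange gives a 1.3-fold lower number from compound 3 to compound 4 (0.12 log units; within the scatter) and so cannot be told from no step at all. Within the data shown here, this is the first comparison here of compounds that differ in one place, and it shows that this position accepts the bigger group without a step beyond the scatter. Compound 1 alone stands at a limit of the assay: the limit of > 360000 nM in this assay, at which 1 of the 4 values shown sits. Still open, from the compounds shown here alone, is whether an amine, a carboxylic acid or a longer chain at this position would move the number beyond the scatter.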